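Swapping One Group on a Shared Core

A few compounds are considered here, and "the series" means these few. Any claim that something is new, unique, unknown or untested is made for them only; others in the source may bear on it.

Compound 1 `CN(C)Cc1cccc(/C=N/Nc2ncnc3sc(C(C)(C)C)cc23)n1` gives 0.419 ug/mL in a functional assay on HCT-116 cells (Homo sapiens) for cytotoxicity, read by MTT assay, with a stated time of 3 days; a higher number here means a weaker inhibitor, a lower number a stronger inhibitor.
Compound 2 `CN(C)Cc1ccc(/C=N/Nc2ncnc3sc(C(C)(C)C)cc23)cc1` gives 0.128 ug/mL in this assay.

Compound 2 has the lowest number of the two; compound 1 stands a good way above it, beyond the usual scatter. Compound 3 `CN(C)S(=O)(=O)c1ccc(/C=N/Nc2ncnc3sc(C(C)(C)C)cc23)cc1` differs from compound 2 in one place: dimethylsulfamoyl in place of (dimethylamino)methyl on an aromatic carbon. Among the compounds with values here, no measured pair shows this swap, so its effect is unknown. A modest step toward a higher number is expected, a 2.7-fold higher number from compound 2 to compound 3 (0.44 log units; beyond the scatter), with wide uncertainty. Compound 3 is therefore estimated at 0.35 ug/mL in this assay, within 0.08 ug/mL to 1.5 ug/mL.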

Compound 3, half-maximal inhibitory concentration: 1.42 ug/mL
Estimate against measurement, compound 3: 4.1-fold (0.61 log units) below; the range from low to high includes it.
By their numbers in this assay, from the lowest: compound 2; then compound 1; then compound 3.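

In this assay, this position on the shared core proves sensitive to what it carries: dimethylsulfamoyl in place of (dimethylamino)methyl gives an 11-fold higher number from compound 2 to compound 3 (1.05 log units; beyond the scatter) and so a much weaker inhibitor. Neither group has a ring, a net charge or a hydrogen-bond donor, so these features do not tell the two apart. Nothing measured here gives a reason for the size of this step.

On these data alone, whether a primary amine, a carboxylic acid or a longer chain at this position would keep the number close to that of compound 2 remains open.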